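Swapping a cyclohexylmethyl for an oxan-4-yl ring

The compounds below may be only part of what the source reports. "The series", "measured", "known", "first", "only" and "open" are said of these compounds alone.

Of the compounds shown here, three built on the same core have been tested in an assay on isolated protein for inhibition of tyrosine-protein kinase receptor UFO (Homo sapiens), read by ELISA; on this read-out higher numbers stand for weaker inhibition and lower numbers for stronger inhibition. Compound 1 `Cn1cc(-c2ccc(NC(=O)c3cn(CC4CCCCC4)cc(-c4ccc(F)cc4)c3=O)cc2)c2c(N)ncnc21` gives 2.3 nM. Compound 2 `Cn1cc(-c2ccc(NC(=O)c3cn(CC4CCOCC4)cc(-c4cccc(F)c4)c3=O)cc2)c2c(N)ncnc21` gives 3 nM in this assay, a number that lies within the usual scatter of compound 1. Compound 3 `Cc1nc(N)c2c(-c3ccc(NC(=O)c4cn(CC5CCOCC5)cc(-c5ccc(F)cc5)c4=O)cc3)cn(C)c2n1` gives 5.1 nM in this assay, which sits beyond the scatter of compound 1. Compound 1 thus stands at the low end of the three numbers, with compound 2 close to it and compound 3 further off. Compounds 2 and 3 differ from compound 1 in more than one place at once, so their values show only where they sit, not what any single change does.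

Compound 4 `Cn1cc(-c2ccc(NC(=O)c3cn(C4CCOCC4)cc(-c4ccc(F)cc4)c3=O)cc2)c2c(N)ncnc21` has not yet been measured. It differs from compound 1 in one place: oxan-4-yl in place of cyclohexylmethyl on an aromatic nitrogen. Among the compounds with values here, no measured pair shows this exact change on its own. Because compound 2 holds an oxygen-containing ring at that nitrogen and gives 3 nM, a ring with an oxygen atom at this position appears to be tolerated, and the step is expected to be small, if anything a modest move toward a higher number. Compound 4 is therefore estimated at 4 nM in this assay, within a range of 1.5 nM to 12 nM, meaning an expected step of a 1.7-fold higher number from compound 1 to compound 4 (0.24 log units; within the scatter).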

Compound 4, half-maximal inhibitory concentration: 1.1 nM
Estimate against measurement, compound 4: 3.6-fold (0.56 log units) above; measured number below the stated range.
By their numbers in this assay, from the lowest: compound 4; then compounds 1, 2 and 3 (each within the scatter of the next, the first and the last beyond it).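

In this assay, within the data shown here, placing oxan-4-yl on the aromatic nitrogen in place of cyclohexylmethyl gives a 2.1-fold lower number from compound 1 to compound 4 (0.32 log units; beyond the scatter) and, unlike the earlier comparisons, isolates a single change at this position on an otherwise unchanged compound. The step shows that this position does not depend on an all-carbon ring: the group carrying a ring oxygen, with one hydrogen-bond acceptor where the group it replaces has none, gives a number that is lower and beyond the scatter. The swap also removes the carbon link between the ring and the nitrogen, so the step cannot separate the effect of the ring oxygen from that of the shorter attachment, and nothing available here explains the shift.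

Oxan-4-ylmethyl on the exact core of compound 1 would help divide the step between those two parts, while a cyclohexyl group directly on the nitrogen would test the same question from the other side. A piperidin-4-yl ring, with an amine in place of the ring oxygen, or a longer chain ending in a carboxylic acid could show how far this position accepts other groups.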